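The compounds below may be only part of what the source reports. "The series", "measured", "known", "first", "only" and "open" are said of these compounds alone.

Measured compounds in a functional assay on cells for positive allosteric modulation of G-protein coupled receptor 68 (Homo sapiens), read by a luciferase reporter and cAMP accumulation, with a stated time of 30 min, at pH 6.8 and pH 8.3, in the presence of a further agent that is not named here; a higher number here means a more potent compound, by a factor of ten per unit of this negative logarithm, a lower number a less potent compound:

Compound 1, `Nc1nc(NCc2ccccc2)nc(-c2ccc(F)cc2CO)n1`, gives 4.58.
Compound 2, `COc1ccc(-c2nc(N)nc(NCc3ccccc3)n2)c(CO)c1`, gives 4.12.
Compound 3, `Nc1nc(NCc2ccccc2F)nc(-c2ccccc2CO)n1`, gives 4.27.

Among these three numbers compound 3 stands second highest. Its nearest neighbour is compound 2, whose value is within the usual scatter of it, while compound 1 lies beyond the scatter above it.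

The new compound is compound 4, `COc1cccc(CNc2nc(N)nc(-c3ccccc3CO)n2)c1`. It differs from compound 3 in one place: 3-methoxyphenyl in place of 2-fluorophenyl on a saturated chain carbon bound to a nitrogen on an aromatic ring.

Going by the values given here, only one measured step offers any guide. The step of a number 0.46 log units lower from compound 1 to compound 2 (beyond the scatter) also swaps a methoxy for a fluoro, but on the other aromatic ring of the shared core, so it bears on the present change only loosely. That step was modest and downward. Among the compounds with values here, the swap in compound 4 sits on the ring attached to the saturated chain carbon, and no measured pair tests that ring directly. Given this, a small downward drift, or no step beyond the scatter, is the expected outcome for compound 4 in this assay, with the step of a number 0.07 log units lower from compound 3 to compound 4 (within the scatter) expected. The estimate for compound 4 is 4.2, with a range from 3.7 to 4.7.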

Compound 4, negative logarithm of the antagonist equilibrium constant: 4.11
For compound 4 the middle estimate is 0.09 log units above the measured one, within the range that was stated.
By their numbers in this assay, from the lowest: compounds 4, 2 and 3 (each within the scatter of the next); then compound 1.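

In this assay, going by these compounds alone, the change on the saturated chain carbon gives a number 0.16 log units lower from compound 3 to compound 4 (within the scatter), so this is the first direct test of that ring and it shows no step that can be told apart from repeat measurements. The entering 3-methoxyphenyl has one hydrogen-bond acceptor and the leaving 2-fluorophenyl has none, yet this difference comes with no step beyond the scatter here. No measured property of these groups is available to interpret this result.

The step changes both the group on the ring and its place, so the compounds shown cannot separate the two; 3-fluorophenyl or 2-methoxyphenyl at this position would do so. Going by these compounds, how a phenyl ring carrying a carboxylic acid or an amine would read here also remains open.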